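This account rests on a few compounds, and the source may have more. Where it says the series, first, only, none or still open, it means among the compounds named here.

In an in vitro ADME assay on microsomes from liver (Homo sapiens) for metabolic stability, using NADPH (on this read-out lower numbers stand for slow clearance and higher numbers for fast clearance), compound 1 `CC(C)(CO)CNC(=O)c1cc2cc(C#N)ccc2n1Cc1cccc(OC(F)(F)F)c1` gives 62 mL.min-1.g-1 and compound 2 `COc1ccc(OC(F)(F)F)cc1Cn1c(C(=O)NCC(C)(C)CO)cc2cc(C#N)ccc21` gives 69 mL.min-1.g-1, so the two sit within the usual scatter of each other and neither can be ranked on these numbers. Compound 3 `N#Cc1ccc2c(c1)cc(C(=O)NCCC(O)(C(F)(F)F)C(F)(F)F)n2Cc1cccc(OC(F)(F)F)c1` keeps the core of compound 1 and changes only the chain on the amide-type nitrogen: 3,3,3-trifluoro-2-hydroxy-2-(trifluoromethyl)propyl in place of 1-(hydroxymethyl)-1-methylethyl on a saturated chain carbon bound to an amide-type nitrogen. Going by the values given here, the only measured step, with methoxy in place of hydrogen on an aromatic carbon, is a 1.1-fold higher number from compound 1 to compound 2 (0.05 log units; within the scatter). It does not touch this chain, so no measurement shows directly what the new chain does to clearance. With no evidence for a direction, no change beyond the scatter is expected. The expected result is a 1.1-fold lower number from compound 1 to compound 3 (0.05 log units; within the scatter). For compound 3 the estimated clearance is 55 mL.min-1.g-1, with an expected range of 22 mL.min-1.g-1 to 130 mL.min-1.g-1, kept wide for the lack of direct evidence.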

Compound 3, intrinsic clearance in microsomes: 20 mL.min-1.g-1
Estimate against measurement, compound 3: 2.8-fold (0.44 log units) above; the whole stated range lies above it.
By their numbers in this assay, from the lowest: compound 3; then compounds 1 and 2 (each within the scatter of the next).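

The chain on the amide-type nitrogen turns out to be a place where clearance responds: in this assay putting 3,3,3-trifluoro-2-hydroxy-2-(trifluoromethyl)propyl in place of 1-(hydroxymethyl)-1-methylethyl gives a 3.1-fold lower number from compound 1 to compound 3 (0.49 log units; beyond the scatter), whereas the methoxy step on the aromatic carbon stayed within the scatter. Both chains count one hydrogen-bond donor and one acceptor and carry no net charge, so the visible difference between them is the six fluorine atoms and the larger heavy-atom count. Nothing measured here explains why the number falls.

The fluorine atoms and the rest of the chain change together in this single step, so the compounds shown cannot separate their contributions. Also open, from the compounds shown here alone, is how a chain ending in an amine or a carboxylic acid would read out at this place, and whether the new chain gives a similar step on compound 2.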